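Shortening an ester-bearing side chain: what to expect

A few compounds are considered here, and "the series" means these few. Any claim that something is new, unique, unknown or untested is made for them only; others in the source may bear on it.

Compound 1, `CC(C)[C@H](NC(=O)CN(c1nc(Cl)nc2[nH]cnc12)C1CC1)C(=O)OCc1ccccc1`, gives 33.4% in a functional assay on the whole organism (Tail, strain ICR) with Mus musculus as the target, in the tail flick test, with a stated time of 30 min, at a dose of 25 umol/kg by the oral route; a higher number here means a stronger effect of the compound at the dose given, a lower number a weaker effect.
Compound 2, `O=C(CN(c1ncnc2c1ncn2C1CCCCO1)C1CC1)N[C@@H](CCC(=O)OCc1ccccc1)C(=O)OCc1ccccc1`, gives 32.6% in this assay.
Compound 3, `NC(=O)C[C@H](NC(=O)CN(c1nc(Cl)nc2[nH]cnc12)C1CC1)C(=O)O`, gives 29.7% in this assay.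

In this assay compound 2 stands second highest of the three numbers; compound 1 lies slightly above it and compound 3 slightly below, but both gaps fall within the usual scatter, so the three compounds cannot be told apart on this evidence. Compound 4, `O=C(CN(c1ncnc2c1ncn2C1CCCCO1)C1CC1)N[C@@H](CC(=O)OCc1ccccc1)C(=O)OCc1ccccc1`, has not been measured. It differs from compound 2 in one place: benzyloxycarbonyl in place of (benzyloxycarbonyl)methyl on a saturated chain carbon, two bonds along the chain from an amide-type nitrogen and a carbonyl carbon. Within the data shown here, no measured pair in this set differs at a single place, so no step size has been observed directly. With all three measured compounds sitting close together, a step from compound 2 to compound 4 no larger than the scatter, in either direction, is expected. Compound 4 is therefore expected to give about 31%, within a range of 18% to 44%. The expected step is a number 1.6 percentage points lower from compound 2 to compound 4 (within the scatter).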

Compound 4, a percentage reported as activity, at one dose (the size of the read-out at that dose, not a potency): 31.8%
Beside the measured number, compound 4's estimate is 0.8 percentage points below it; the measured number falls inside the stated range.
By their numbers in this assay, from the lowest: compounds 3, 4, 2 and 1 (each within the scatter of the next).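

Among these compounds, compounds 2 and 4 form the first pair that differs in only one place, so the effect of a change can now be read directly. In this assay, among the compounds shown here, benzyloxycarbonyl in place of (benzyloxycarbonyl)methyl on this saturated chain carbon gives a number 0.8 percentage points lower from compound 2 to compound 4 (within the scatter), so this shortening of the ester-bearing side chain produces no step that can be told from the scatter. No evidence here bears on this result.

Still open, on these data alone, is whether an amine at this place would behave the same way. The same question applies to a chain longer than 2-(benzyloxycarbonyl)ethyl.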